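Swapping a Selenium Chain for an Amine on Compound 1

This account rests on a few compounds, and the source may have more. Where it says the series, first, only, none or still open, it means among the compounds named here.

Among the measured compounds shown here, compound 1 `CCCCC[Se]c1nc([Se]CCCCC)c2ccccc2n1` was tested in a functional assay on MCF7 cells (Homo sapiens) for cytotoxicity, read by MTT assay, with a stated time of 72 h (a higher number here means a weaker inhibitor of growth, a lower number a stronger inhibitor of growth), where compound 1 gives 95100 nM, the only actual number in this small set. Compound 2 `[SeH]c1nc(NCc2ccccc2)c2ccccc2n1` in this assay gives > 100000 nM, which is a limit of the assay and not a number. The remaining information is the limit of > 100000 nM in this assay, at which 1 of the 2 values shown sits. Compound 3 `CCCCC[Se]c1nc(N)c2ccccc2n1` has not yet been tested. It differs from compound 1 by one nitrogen atom in place of a group of 6 heavy atoms (5 carbon, 1 selenium; no ring), on an aromatic carbon. For the measured compounds named here, no measured pair shows this change, so nothing indicates how large its effect is. Starting from compound 1, the expected step is a 1.2-fold higher number from compound 1 to compound 3 (0.06 log units; within the scatter), small or, if anything, toward weaker inhibition of growth. Compound 3 is therefore estimated at 110000 nM, with a likely range from 40000 nM to 300000 nM.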

Compound 3, concentration for total growth inhibition: 59500 nM
Compound 3: middle estimate off by 1.8-fold (0.27 log units), on the high side, and the stated range covers the measured number.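

In this assay, amino in place of the group of 6 heavy atoms (5 carbon, 1 selenium; no ring) gives a 1.6-fold lower number from compound 1 to compound 3 (0.20 log units; within the scatter), so the two compounds cannot be told apart. Among the compounds shown here, this is the first measured pair for this change, and it shows that this selenium chain can leave this aromatic carbon, replaced by a single nitrogen atom, while the number stays within the scatter of the starting compound. Nothing measured here gives a reason for this result.

Going by these compounds, whether a methylamino group, a hydroxyl group or a longer selenium chain on this carbon would move the number beyond the scatter remains open. So does the effect of replacing the selenium chain that compound 1 and compound 3 share.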